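Amide nitrogen substituent in the fluorophenyl dihydrofuran series

The compounds below may be only part of what the source reports. "The series", "measured", "known", "first", "only" and "open" are said of these compounds alone.

In a functional assay on QGY7701 cells (Homo sapiens) for cytotoxicity, read by MTT assay, with a stated time of 24 h (a lower number here means a stronger inhibitor, a higher number a weaker inhibitor), compound 1 `C=CC1=C(C(=O)Nc2ccccc2OC)C(c2ccc(F)cc2)OC1` gives 52800 nM and compound 2 `C=CC1=C(C(=O)Nc2ccccc2)C(c2ccc(F)cc2)OC1` gives 46700 nM. Compound 3 `C=CC1=C(C(=O)NC(C)(C)C)C(c2ccc(F)cc2)OC1` sits at the limit of > 100000 nM in this assay, at which 1 of the 3 values shown sits; its value > 100000 nM is a limit of this assay, not a number. Compound 3 therefore stands at the weak end of what is shown: an at least 2.1-fold higher number from compound 2 to compound 3 (0.33 log units; beyond the scatter) and an at least 1.8-fold higher number from compound 1 to compound 3 (0.27 log units; that floor lies within the scatter).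

Compound 4 `C=CC1=C(C(=O)NCc2ccccc2)C(c2ccc(F)cc2)OC1` differs from compound 3 by benzyl in place of tert-butyl on an amide-type nitrogen. Among the measured compounds shown here, the steps that bear on it run the other way, from an aromatic amide substituent to tert-butyl, and both gave higher numbers. Returning an aromatic ring, now as benzyl, is expected to bring the number back toward those of compound 2 and compound 1, so compound 4 is expected at 60000 nM (range 25000 nM to 150000 nM), meaning an at least 1.6-fold lower number from compound 3 to compound 4 (0.22 log units; that floor lies within the scatter) as the estimated step.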

Compound 4, half-maximal inhibitory concentration: 67600 nM
Compound 4: the middle estimate sits 1.1-fold (0.05 log units) below what was measured; the measured number falls inside the stated range.
By their numbers in this assay, from the lowest: compounds 2, 1 and 4 (each within the scatter of the next). At a limit, above all of these: compound 3.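

In this assay, benzyl on the amide-type nitrogen cannot be told apart from the directly attached aromatic groups: a 1.4-fold higher number from compound 2 to compound 4 (0.16 log units; within the scatter) and a 1.3-fold higher number from compound 1 to compound 4 (0.11 log units; within the scatter). Against tert-butyl, the step is only a floor, an at least 1.4-fold lower number from compound 3 to compound 4 (0.17 log units; that floor lies within the scatter), so a real separation of benzyl from tert-butyl is not established. Compound 3 remains at a limit, not a number: the limit of > 100000 nM in this assay, at which 1 of the 4 values shown sits.

Open, going by these compounds, is whether phenethyl, a longer chain ending in phenyl, would stay level with compound 4. Also open, on these data alone, is whether a benzyl bearing a carboxylic acid would give a number set apart from compound 1, compound 2 and compound 4.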